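From Pyridin-2-yl to tert-Butoxy on a Shared Core

The source may report more compounds than this note shows. Statements on the series, on what has been measured and on what is new or still open speak of the compounds shown alone.

Of the compounds shown here, three built on one shared core have been tested in an ADME assay on Caco-2 cells (Homo sapiens) for permeability, read by LC-MS, in the apical to basolateral direction, with a stated time of 60 min, at pH 6.5; on this read-out higher numbers stand for higher permeability and lower numbers for lower permeability. Compound 1 `O=C(NCc1cc(Cl)ccc1-n1cnnn1)[C@@H]1C[C@@H]2C[C@@H]2N1C(=O)[C@H](O)Cc1ccccn1` gives 1.2 10^-6 cm/s, the lowest of the three numbers. Compound 3 `CC1(C[C@@H](O)C(=O)N2C[C@H]3C[C@H]3[C@H]2C(=O)NCc2cc(Cl)ccc2-n2cnnn2)CC1` gives 2.2 10^-6 cm/s, a number that lies within the scatter of that of compound 1, so the two cannot be told apart. Compound 2 `CC(C)(C)C[C@@H](O)C(=O)N1[C@@H]2C[C@@H]2C[C@H]1C(=O)NCc1cc(Cl)ccc1-n1cnnn1` gives 24 10^-6 cm/s, a number that stands beyond the scatter above compound 1.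

The next step leads from compound 1 to compound 4 `CC(C)(C)OC[C@@H](O)C(=O)N1[C@H](C(=O)NCc2cc(Cl)ccc2-n2cnnn2)C[C@@H]2C[C@@H]21`, which has not yet been measured in this assay. The change is tert-butoxy in place of pyridin-2-yl on a saturated chain carbon, two bonds along the chain from a carbonyl carbon and an oxygen on a saturated carbon.

Among the compounds with values here, since no measured pair shows this exact change, the expectation rests on the three numbers at hand. Compound 2, carrying a saturated chain in place of the aromatic ring of compound 1, gave the highest number, while compound 3 stayed close to compound 1. The tert-butoxy chain of compound 4 resembles neither case exactly, so the expected step is a 5.8-fold higher number from compound 1 to compound 4 (0.77 log units; beyond the scatter), a moderate rise. Compound 4 is therefore estimated at 7 10^-6 cm/s, with a range from 2.5 10^-6 cm/s to 20 10^-6 cm/s.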

Compound 4, apparent permeability: 4.5 10^-6 cm/s
For compound 4 the middle estimate is 1.6-fold (0.19 log units) above the measured one, within the range that was stated.
By their numbers in this assay, from the lowest: compounds 1 and 3 (each within the scatter of the next); then compound 4; then compound 2.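

Within the data shown here, this is the first pair in the set that differs in one place only, so it gives the first direct reading of this position: tert-butoxy in place of pyridin-2-yl on the saturated chain carbon gives a 3.8-fold higher number from compound 1 to compound 4 (0.57 log units; beyond the scatter) in this assay. The number therefore does move with the group at this place, even though the shared core and the rest of the molecule stay the same. The swap removes the aromatic ring while the counts of hydrogen-bond donors and acceptors stay equal on both sides, but nothing measured here tells what lies behind the rise.

A single step cannot show whether the rise goes with losing the ring nitrogen, losing the aromatic ring as a whole, or gaining the tert-butoxy group itself, and phenyl on the same chain carbon would help to separate the first two of these. Also open, on these data alone, is how the read-out would respond at this place to a charged group, such as a dimethylamino group or a carboxylic acid.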